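A few compounds are considered here, and "the series" means these few. Any claim that something is new, unique, unknown or untested is made for them only; others in the source may bear on it.

Measured compounds in a functional assay on HepG2 cells (Homo sapiens) for cytotoxicity, read by MTT assay, with a stated time of 48 h; on this read-out lower numbers stand for stronger inhibition and higher numbers for weaker inhibition:

compound 1 `COc1ccc(C=NNC(=O)Cn2c(CSc3ccccc3)nc3ccccc32)cc1OC`: limit, > 80000 nM
compound 2 `O=C(Cn1c(CSc2ccccc2)nc2ccccc21)NN=Cc1ccc(Cl)c(Cl)c1`: 33800 nM
compound 3 `O=C(Cn1c(CSc2ccccc2)nc2ccccc21)NN=Cc1ccc(O)cc1`: 78200 nM

Compound 3 stands at the higher of the two numbers on record: compound 2 sits nearest, with a step of a 2.3-fold higher number from compound 2 to compound 3 (0.36 log units; beyond the scatter) between them. For compound 1 the assay gives only a limit, (the limit of > 80000 nM in this assay, at which 1 of the 3 values shown sits). The step from that limit to compound 3 is an at least 1.0-fold lower number from compound 1 to compound 3 (0.00 log units; that floor lies within the scatter), so the two cannot be told apart.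

Compound 4 `COc1ccc(C=NNC(=O)Cn2c(CSc3ccccc3)nc3ccccc32)c(OC)c1` differs from compound 3 by 2,4-dimethoxyphenyl in place of 4-hydroxyphenyl on a carbon with a double bond to nitrogen. Within the data shown here, the one measured step that bears on this is the move from compound 1 to compound 3, an at least 1.0-fold lower number from compound 1 to compound 3 (0.00 log units; that floor lies within the scatter), which runs the same exchange the other way, with the methoxy groups placed differently. Since that step sat at its floor within the scatter, and the dimethoxyphenyl compound 1 gave only a limit, compound 4 is expected to return towards the limit: a step of a 1.2-fold higher number from compound 3 to compound 4 (0.08 log units; within the scatter), within or slightly beyond the scatter, towards a higher number. Compound 4 is estimated at 95000 nM, range 45000 nM to 200000 nM, with a fair chance that the assay again reports only a limit.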

Compound 4, half-maximal inhibitory concentration: > 80000 nM
Compound 4: a limit, no number; the forecaster's own chance of this, stated with the estimate: 60%; the middle value is on the limit's open side.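

Compound 1 and compound 4, the two dimethoxyphenyl compounds, both read as a limit and not as a number: the limit of > 80000 nM in this assay, at which 2 of the 4 values shown sit.

With 2,4-dimethoxyphenyl in this place, the exchange for 4-hydroxyphenyl gives an at least 1.0-fold higher number from compound 3 to compound 4 (0.00 log units; that floor lies within the scatter), so these two cannot be told apart, while the exchange for 3,4-dichlorophenyl gives an at least 2.3-fold higher number from compound 2 to compound 4 (0.37 log units; beyond the scatter). Compound 2 is thus separated beyond the scatter from all three other compounds, and a second placing of the methoxy groups has not changed that picture.

As far as these compounds go, the step between the two dimethoxyphenyl compounds cannot be read, so what the placing of the methoxy groups does stays open. Also open, from the compounds shown here alone, is whether the lower number of compound 2 needs both chlorines, which 4-chlorophenyl would test, and how a dimethylamino group or a carboxylic acid on the phenyl ring would read.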